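This account rests on a few compounds, and the source may have more. Where it says the series, first, only, none or still open, it means among the compounds named here.

Measured so far:
compound 1, `C=Cc1ccc(S(=O)(=O)Nc2ccc3oc(-c4ccccc4)nc3c2)cc1`, gives > 100000 nM
compound 2, `O=S(=O)(Nc1ccc2oc(-c3ccccc3)nc2c1)c1cccc(F)c1`, gives > 100000 nM

In an assay on cells for inhibition of HSP60/HSP10 (Homo sapiens), with a stated time of 60 min (a higher number here means a weaker inhibitor, a lower number a stronger inhibitor), compound 1 returns only a limit, > 100000 nM. Compound 2 likewise returns only a limit in this assay, namely > 100000 nM. For the measured compounds named here, the one measured step, a step that the two limits leave unreadable from compound 1 to compound 2, therefore has no readable size, since (the limit of > 100000 nM in this assay, at which 2 of the 2 values shown sit). Going by the values given here, compound 2 thus stands at the limit of this assay with no number of its own, and the one further value shown is also a limit.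

Compound 3, `O=S(=O)(Nc1ccc2oc(-c3ccccc3)nc2c1)c1ccc(Cl)cc1`, differs from compound 2 in one place: 4-chlorophenyl in place of 3-fluorophenyl on a sulfonyl sulfur. Among the compounds with values here, only the step that the two limits leave unreadable from compound 1 to compound 2 bears on this change, and as in that step one phenyl group replaces another on a sulfonyl sulfur; its size is not readable. Within the data shown here, no measured step gives a direction beyond the scatter, so compound 3 is expected to sit at the limit as well. Compound 3 is therefore estimated at 100000 nM, within 20000 nM to 300000 nM. This estimate implies an expected step of a number no higher from compound 2 to compound 3 (the limit leaves the size open).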

Compound 3, half-maximal inhibitory concentration: > 100000 nM
Compound 3 ended at the assay's limit (the forecaster's own chance of this, stated with the estimate: 85%); the middle value lies on the limit itself.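

In this assay compound 3 also returns only a limit, so neither its step from compound 1 nor its step from compound 2 can be read: the limit of > 100000 nM in this assay, at which 3 of the 3 values shown sit.

The compounds shown leave open whether any group on the sulfonyl sulfur gives a measurable number in this assay rather than a limit.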